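The compounds below may be only part of what the source reports. "The series", "measured", "known", "first", "only" and "open" are said of these compounds alone.

In a functional assay on A549 cells (Homo sapiens) for cytotoxicity, read by MTT assay, with a stated time of 48 h (on this read-out higher numbers stand for weaker inhibition and lower numbers for stronger inhibition), compound 3 `COc1c(OCCCCN2CCCCC2)cc(O)c2c(=O)cc(-c3ccccc3)oc12` gives 1150 nM, and compound 1 `COc1c(OCCCCN2CCNCC2)cc(O)c2c(=O)cc(-c3ccccc3)oc12` gives 1740 nM, so the two stand level within the scatter. Compound 2 `COc1c(OCc2nc3ccccc3[nH]2)cc(O)c2c(=O)cc(-c3ccccc3)oc12` reads > 100000 nM, which is a limit of the assay. Compound 4 `COc1c(OCCCNCc2ccccc2)cc(O)c2c(=O)cc(-c3ccccc3)oc12` differs from compound 3 as follows: benzylamino in place of (piperidin-1-yl)methyl on a saturated chain carbon, three bonds along the chain from an oxygen on an aromatic ring. This puts benzylamino in place of (piperidin-1-yl)methyl on a saturated chain carbon. Going by the values given here, the closest precedent, a 1.5-fold lower number from compound 1 to compound 3 (0.18 log units; within the scatter), exchanged one ring at the chain end for another and stayed within the scatter. The large at least 86-fold lower number from compound 2 to compound 3 (1.93 log units; beyond the scatter) replaced 1H-benzimidazol-2-yl with a nitrogen-bearing chain, and compound 4 keeps such a chain. In this assay the expected result is a 1.7-fold higher number from compound 3 to compound 4 (0.24 log units; within the scatter), no step beyond the scatter. For compound 4 the estimated value is 2000 nM, with an expected range of 700 nM to 8000 nM.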

Compound 4, half-maximal inhibitory concentration: 1570 nM
The estimate for compound 4 lay 1.3-fold (0.11 log units) above the measured number; low and high end bracket the measured number.
By their numbers in this assay, from the lowest: compounds 3, 4 and 1 (each within the scatter of the next). At a limit, above all of these: compound 2.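

In this assay, benzylamino brings an aromatic ring of carbon only and a hydrogen-bond donor in place of (piperidin-1-yl)methyl, yet the result stays within the scatter (a 1.4-fold higher number from compound 3 to compound 4 (0.14 log units; within the scatter)). The same holds against the piperazin-1-yl chain (a 1.1-fold lower number from compound 1 to compound 4 (0.04 log units; within the scatter)), so compounds 1, 3 and 4 stand level even though the group at the chain end differs. The large gap to the benzimidazole compound remains (an at least 63-fold lower number from compound 2 to compound 4 (1.80 log units; beyond the scatter)), and the value of compound 2 is a limit. Still open, as far as these compounds go, is whether the chain needs its nitrogen at all: a chain ending in a hydroxyl group or a carboxylic acid would test that.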